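Hydroxamic acid series: methoxy in place of acetamido

This account rests on a few compounds, and the source may have more. Where it says the series, first, only, none or still open, it means among the compounds named here.

The series shares the core of compound 1 `COc1ccccc1CN1CCC=C(CCC(=O)NO)C1=O`, which in a functional assay on MDA-MB-231 cells (Homo sapiens) for inhibition, read by sulforhodamine B assay (a lower number here means a stronger inhibitor of growth, a higher number a weaker inhibitor of growth), reaches only the limit of > 10000 nM. Compound 2 `O=C(CCC1=CCCN(Cc2ccc(F)cc2)C1=O)NO` is recorded with "not determined" (no result reported) in this assay. Compound 3 `CC(=O)Nc1ccc(CN2CCC=C(CCC(=O)NO)C2=O)cc1` likewise carries "not determined" (no result reported) in this assay. Where compound 3 stands on the numbers shown: no single number exists for it; of the three entries, one further value is a limit and one further entry has no number, so compound 3 cannot be placed against any neighbour, and the only measured point in the set is the limit (the limit of > 10000 nM in this assay, at which 1 of the 3 values shown sits).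

Compound 4 `COc1ccc(CN2CCC=C(CCC(=O)NO)C2=O)cc1` differs from compound 3 by methoxy in place of acetamido on an aromatic carbon. Among the compounds with values here, no step between measured compounds is available, so the size of this change in this assay cannot be read from the data. Within the data shown here, the expectation is a step of no more than the scatter in this assay, in no settled direction, since the sole measured value in the set, that of compound 1, is the limit of > 10000 nM in this assay, at which 1 of the 3 values shown sits, and gives no scale for the change. Compound 4 is therefore expected at 8000 nM, within 2000 nM to 30000 nM, with a real chance that this assay again reports only a limit.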

Compound 4, concentration for 50% growth inhibition: 3860 nM
Compound 4: the middle estimate sits 2.1-fold (0.32 log units) above what was measured; the range from low to high includes it.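

Within the data shown here, compound 4 gives 3860 nM in this assay, but compound 3 has no single number there, so no step from compound 3 to compound 4 can be read. The compounds shown leave open what methoxy in place of acetamido does to growth inhibition, and how compound 4 compares with the only other entry, which is a limit: the limit of > 10000 nM in this assay, at which 1 of the 4 values shown sits.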